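A Second Bromo Group on the Shared Core

The source may report more compounds than this note shows. Statements on the series, on what has been measured and on what is new or still open speak of the compounds shown alone.

Compound 1 `Cc1cccc2c1OCN(c1ccc3oc(-c4ccccc4)cc(=O)c3c1)C2`: 72.4%
Compound 2 `COc1cccc2c1OCN(c1ccc3oc(-c4ccccc4)cc(=O)c3c1)C2`: 67.8%
Compound 3 `O=c1cc(-c2ccccc2)oc2ccc(N3COc4c(Br)cccc4C3)cc12`: 71.6%

Of the compounds shown here, three have been measured in a functional assay on MCF7 cells (Homo sapiens) for inhibition, read by MTT assay, with a stated time of 48 h, tested at 30 ug/mL (on this read-out lower numbers stand for less inhibition of growth and higher numbers for more inhibition of growth at the one concentration tested), and all three numbers differ from one another only within the scatter. For the measured compounds named here, compound 3 sits among them with a step of a number 0.8 percentage points lower from compound 1 to compound 3 (within the scatter) and a step of a number 3.8 percentage points higher from compound 2 to compound 3 (within the scatter); no compound here can be called more or less active than another.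

Compound 4 `O=c1cc(-c2ccccc2)oc2ccc(N3COc4c(Br)cc(Br)cc4C3)cc12` is not yet measured. It differs from compound 3 by bromo in place of hydrogen on an aromatic carbon. The measured steps that bear on it are those exchanging one aromatic substituent for another on the same ring, a number 4.6 percentage points lower from compound 1 to compound 2 (within the scatter) and a number 3.8 percentage points higher from compound 2 to compound 3 (within the scatter), each within the scatter. Going by the values given here, no measured step adds a second bromo group in place of hydrogen, so the account rests on the flatness seen so far.

The step from compound 3 to compound 4 is therefore expected to be small, a number 0.6 percentage points lower from compound 3 to compound 4 (within the scatter), in no firm direction. Compound 4 is estimated at 71%, with a range from 58% to 82%.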

Compound 4, percent growth inhibition at one concentration: 16.1%
Estimate against measurement, compound 4: 54.9 percentage points above; the whole stated range lies above it.
By their numbers in this assay, from the lowest: compound 4; then compounds 2, 3 and 1 (each within the scatter of the next).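

In this assay the second bromo group is the first change among these compounds to give a step beyond the scatter, with a number 55.5 percentage points lower from compound 3 to compound 4 (beyond the scatter) on adding this single atom. The earlier steps shown here only exchanged one substituent for another, whereas here a hydrogen of the ring gives way to a new bromo group, meta to a bromo group, and this shows that a position carrying hydrogen in compound 1, compound 2 and compound 3 is far from indifferent to substitution. Nothing measured here accounts for this loss of growth inhibition.

Going by these compounds, whether chloro, an amine or a carboxylic acid at this position would give an equally low number stays open. Equally open, on these data alone, is whether the step would keep its size with methyl or methoxy in place of the first bromo group.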